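Methyl on the ring amine of compound 1: expected binding shift

A few compounds are considered here, and "the series" means these few. Any claim that something is new, unique, unknown or untested is made for them only; others in the source may bear on it.

In an assay on HEK293 cells for displacement of a labelled ligand from Neuronal acetylcholine receptor; alpha3/beta4 (Homo sapiens), read by scintillation counting (a lower number here means a stronger inhibitor, a higher number a weaker inhibitor), compound 1, `COc1ncccc1OC[C@@H]1CCCN1`, gives 5300 nM, the lowest of the two numbers shown. Compound 2, `COc1ccc(O)cc1OC[C@@H]1CCCN1`, gives 7700 nM in this assay, which lies within the scatter of compound 1, so no order between the two can be claimed. Compound 3, `COc1ncccc1OC[C@@H]1CCCN1C`, has not yet been measured. It differs from compound 1 by methyl in place of hydrogen on an amine nitrogen in a ring. The only gap recorded, between compound 1 and compound 2, is within the scatter, and no direction is fixed. Compound 3 is expected to stay close, a 1.3-fold lower number from compound 1 to compound 3 (0.12 log units; within the scatter). The estimate for compound 3 in this assay is 4000 nM, between 1000 nM and 16000 nM.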

Compound 3, inhibition constant: 793 nM
Compound 3: middle estimate off by 5.0-fold (0.70 log units), on the high side; the measured number lies below the stated range.
By their numbers in this assay, from the lowest: compound 3; then compounds 1 and 2 (each within the scatter of the next).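

In this assay methyl in place of hydrogen on an amine nitrogen in a ring gives a 6.7-fold lower number from compound 1 to compound 3 (0.83 log units; beyond the scatter) and so moves the number beyond the scatter. Compound 1 and compound 2 offered no such reading, whereas this single change shows that the ring nitrogen is a place where one added carbon counts. Nothing measured here explains the step.

On these data alone, whether ethyl or a longer chain on this nitrogen would move the number further remains open. So does whether methyl here would have the same effect on the core of compound 2.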